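A few compounds are considered here, and "the series" means these few. Any claim that something is new, unique, unknown or untested is made for them only; others in the source may bear on it.

Series notes on the shared core of compound 1 `Nc1nc(NCc2ccccc2)c2ncn(/C=C3/CC3(CO)CO)c2n1` under the cytotoxicity read-out an ADME assay on HFF cells (Homo sapiens) for cytotoxicity, with a stated time of 8 days; on this read-out higher numbers stand for lower toxicity in this test and lower numbers for higher toxicity in this test. In this assay compound 1 gives > 300000 nM, which is a limit of the assay and not a number. Compound 2 `Nc1nc(OCC(F)(F)F)c2ncn(/C=C3/CC3(CO)CO)c2n1` carries 2,2,2-trifluoroethoxy in place of benzylamino on an aromatic carbon; in this assay compound 2 gives > 300000 nM, again a limit. Compound 3 `CCCCCCSc1nc(N)nc2c1ncn2/C=C1/CC1(CO)CO` carries hexylsulfanyl in place of benzylamino on an aromatic carbon; in this assay compound 3 gives > 300000 nM, also a limit. All three measured values sit at the one limit (the limit of > 300000 nM in this assay, at which 3 of the 3 values shown sit), so the steps a step that the two limits leave unreadable from compound 1 to compound 2, a step that the two limits leave unreadable from compound 1 to compound 3 and a step that the two limits leave unreadable from compound 2 to compound 3 cannot be read for size or direction. Compound 3 thus stands at the limit alongside compound 1 and compound 2. Compound 4 `Nc1nc(SC2CCCC2)c2ncn(/C=C3/CC3(CO)CO)c2n1` differs from compound 3 by cyclopentyl in place of hexyl on a sulfur. The unreadable steps bear on this change only in that no substitution on this aromatic carbon has yet brought a value off the limit. Compound 4 is therefore expected to show a step of a number no higher from compound 3 to compound 4 (the limit leaves the size open), none beyond the scatter. For compound 4 the estimate in this assay is 300000 nM, between 100000 nM and 1000000 nM, most likely reported as a limit once more.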

Compound 4, half-maximal cytotoxic concentration: > 300000 nM
Compound 4 was reported as a limit (the forecaster's own chance of this, stated with the estimate: 85%); the middle value lies on the limit itself.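

In this assay compound 4 stands at the same limit as compound 1, compound 2 and compound 3, so no step among these compounds can be read. The compounds shown leave open whether any substitution on this aromatic carbon brings a value off the limit.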